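The compounds below may be only part of what the source reports. "The series", "measured", "known", "first", "only" and "open" are said of these compounds alone.

Compound 1 `CC1CCN(C2CCN(S(=O)(=O)c3cccc(C(F)(F)F)c3)CC2)CC1`: in a functional assay on DLD-1 cells (Homo sapiens) for antiproliferative activity, read by CellTiter-Glo, with a stated time of 72 h (on this read-out higher numbers stand for weaker inhibition and lower numbers for stronger inhibition), compound 1 gives > 5000 nM, which is a limit of the assay and not a number (the limit of > 5000 nM in this assay, at which 1 of the 3 values shown sits).
Compound 2 `Cc1cccc(S(=O)(=O)N2CCC(N3CCC(C)CC3)CC2)c1`: compound 2 gives 25 nM.
Compound 3 `Cc1cc(C)cc(-c2cccc(S(=O)(=O)N3CCC(N4CCC(C)CC4)CC3)c2)c1`: compound 3 gives 41 nM.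

Compound 3 has the highest of the two numbers shown, and its nearest neighbour is compound 2, separated by a 1.6-fold higher number from compound 2 to compound 3 (0.21 log units; within the scatter). Compound 4 `Cc1ccc(-c2cccc(S(=O)(=O)N3CCC(N4CCC(C)CC4)CC3)c2)cc1` differs from compound 3 by 4-methylphenyl in place of 3,5-dimethylphenyl on an aromatic carbon. For the measured compounds named here, the steps that bear on this change are an at least 120-fold lower number from compound 1 to compound 3 (2.08 log units; beyond the scatter) and an at least 200-fold lower number from compound 1 to compound 2 (2.30 log units; beyond the scatter), both large and both starting from a limit, and the small 1.6-fold higher number from compound 2 to compound 3 (0.21 log units; within the scatter). Swapping one aromatic ring for a closely related one is expected to move the number by no more than the scatter, so compound 4 is estimated at 35 nM, between 14 nM and 90 nM, an expected step of a 1.2-fold lower number from compound 3 to compound 4 (0.07 log units; within the scatter).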

Compound 4, half-maximal inhibitory concentration: 11 nM
Compound 4: the middle estimate sits 3.2-fold (0.50 log units) above what was measured, outside the stated range (below it).
By their numbers in this assay, from the lowest: compound 4; then compounds 2 and 3 (each within the scatter of the next). At a limit, above all of these: compound 1.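

In this assay, the methyl pattern on the added ring matters at this aromatic carbon, meta to a large group: a 3.7-fold lower number from compound 3 to compound 4 (0.57 log units; beyond the scatter). An added ring here can also beat a single methyl, which compound 3 did not show: a 2.3-fold lower number from compound 2 to compound 4 (0.36 log units; beyond the scatter). The value of compound 1 is a limit of the assay, so an at least 450-fold lower number from compound 1 to compound 4 (2.65 log units; beyond the scatter) gives only a bound: the limit of > 5000 nM in this assay, at which 1 of the 4 values shown sits.

What sets 4-methylphenyl apart from 3,5-dimethylphenyl remains unexplained. Also open, as far as these compounds go, is how a ring carrying a methoxy group, a nitrile or an amine would compare with 4-methylphenyl.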